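Chain lengthening on the shared core: notes toward compound 4

The source may report more compounds than this note shows. Statements on the series, on what has been measured and on what is new or still open speak of the compounds shown alone.

The three measured compounds share one core and differ only in a saturated chain bound to an aromatic carbon. Compound 1 `Cc1cnc(-c2nn(Cc3ccccc3F)c3ncccc23)nc1N` carries the shortest chain; in a functional assay (aorta) with Oryctolagus cuniculus as the target (on this read-out higher numbers stand for weaker inhibition and lower numbers for stronger inhibition), compound 1 gives 675000 nM. Compound 2 `CCc1cnc(-c2nn(Cc3ccccc3F)c3ncccc23)nc1N` arises from compound 1 by methyl in place of hydrogen on a saturated chain carbon bound to an aromatic carbon; in this assay compound 2 gives 272000 nM, and the step is a 2.5-fold lower number from compound 1 to compound 2 (0.39 log units; beyond the scatter). Compound 3 `CCCCCc1cnc(-c2nn(Cc3ccccc3F)c3ncccc23)nc1N` differs from compound 1 by butyl in place of hydrogen on a saturated chain carbon bound to an aromatic carbon; in this assay compound 3 gives 200000 nM, the step being a 3.4-fold lower number from compound 1 to compound 3 (0.53 log units; beyond the scatter). Between these two longer chains the step is a 1.4-fold lower number from compound 2 to compound 3 (0.13 log units; within the scatter), so compound 2 and compound 3 cannot be told apart on this read-out.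

Compound 4 `CCCCCCc1cnc(-c2nn(Cc3ccccc3F)c3ncccc23)nc1N` is not yet measured. It differs from compound 3 by methyl in place of hydrogen on a saturated chain carbon, five bonds along the chain from an aromatic carbon. This is the same kind of change as that from compound 1 to compound 2, which gave a 2.5-fold lower number from compound 1 to compound 2 (0.39 log units; beyond the scatter), but not the same place: there the methyl entered on a saturated chain carbon bound to an aromatic carbon, here it enters on a saturated chain carbon five bonds along the chain from an aromatic carbon. A smaller step is expected for compound 4 because a 1.4-fold lower number from compound 2 to compound 3 (0.13 log units; within the scatter) already lies within the scatter, so the expected step is a 1.3-fold lower number from compound 3 to compound 4 (0.10 log units; within the scatter). For compound 4 the estimated value is 160000 nM, expected to fall between 70000 nM and 400000 nM.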

Compound 4, half-maximal inhibitory concentration: 1040000 nM
For compound 4 the middle estimate is 6.5-fold (0.81 log units) below the measured one, outside the stated range (above it).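

In this assay, methyl in place of hydrogen does not carry over as one fixed step from the core of compound 1 to the core of compound 3, and the direction of the step reverses: the same change on two cores in this assay, a 2.5-fold lower number (0.39 log units; beyond the scatter) from compound 1 to compound 2 and a 5.2-fold higher number (0.72 log units; beyond the scatter) from compound 3 to compound 4, 13-fold (1.11 log units) apart, beyond the scatter of two such steps. Butyl in place of hydrogen likewise gives no fixed step between the core of compound 1 and the core of compound 2: the same change on two cores in this assay, a 3.4-fold lower number (0.53 log units; beyond the scatter) from compound 1 to compound 3 and a 3.8-fold higher number (0.58 log units; beyond the scatter) from compound 2 to compound 4, 13-fold (1.11 log units) apart, beyond the scatter of two such steps. The lower numbers of the two shorter longer-chain compounds do not extend to the longest chain shown, as a 5.2-fold higher number from compound 3 to compound 4 (0.72 log units; beyond the scatter) and a 3.8-fold higher number from compound 2 to compound 4 (0.58 log units; beyond the scatter) indicate, while a 1.5-fold higher number from compound 1 to compound 4 (0.19 log units; within the scatter) leaves the two ends of the series indistinguishable; these steps do not show whether the core or the place of entry accounts for the gap, as each pair of steps changes both.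

The compounds shown leave open how the numbers run for a propyl or butyl chain on the aromatic carbon that carries the chain in this series, and whether a longer chain would raise the number further. They also leave open whether a chain ending in an amine or a carboxylic acid would follow the same course in this assay.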